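This account rests on a few compounds, and the source may have more. Where it says the series, first, only, none or still open, it means among the compounds named here.

Notes on the series. In a functional assay on 4T1 cells (Mus musculus) for antiproliferative activity, read by MTT assay, with a stated time of 48 h (a lower number here means a stronger inhibitor, a higher number a weaker inhibitor), compound 1 (`Cc1ccccc1/C=C1\CN(C(=S)NC(=O)c2ccccc2)C/C(=C\c2ccccc2C)C1=O`) gives < 10000 nM as a limit, not a number. Compound 2 (`Cc1ccc(/C=C2\CN(C(=S)NC(=O)c3ccccc3)C/C(=C\c3ccc(C)cc3)C2=O)cc1`) gives < 10000 nM as a limit too. Compound 3 (`CCCCNC(=S)N1C/C(=C\c2ccccc2F)C(=O)/C(=C/c2ccccc2F)C1`) gives < 10000 nM as a limit as well. Compound 2 therefore has no exact value, and neither do the other two: the record is the limit of < 10000 nM in this assay, at which 3 of the 3 values shown sit, and no ranking follows from it.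

Compound 4 (`CCCCNC(=S)N1C/C(=C\c2ccc(C)cc2)C(=O)/C(=C/c2ccc(C)cc2)C1`) comes next, with butyl in place of benzoyl on an amide-type nitrogen. Going by the values given here, no measured step gives the size of this change, so in this assay no shift beyond the scatter is expected, in either direction. Among the compounds with values here, the only anchor is compound 2 with its limit of < 10000 nM and nothing tighter. For compound 4 the estimate is 5000 nM as the expected value, within an expected range of 1500 nM to 10000 nM on the same read-out. The expected change is a step that the limit leaves unreadable from compound 2 to compound 4 when read against that limit, and it remains an estimate only.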

Compound 4, half-maximal inhibitory concentration: < 10000 nM
Compound 4 ended at the assay's limit (the forecaster's own chance of this, stated with the estimate: 50%); the middle value is on the limit's open side.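

The change from compound 2 to compound 4 gives no readable step, because both compounds rest on a limit rather than a number: the limit of < 10000 nM in this assay, at which 4 of the 4 values shown sit.

The compounds shown leave open whether butyl in place of benzoyl shifts activity at all, and how all four compounds rank.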